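The compounds below may be only part of what the source reports. "The series", "measured", "known", "first", "only" and "open" are said of these compounds alone.

For the measured compounds named here, compound 1 `CCCCCCNC(=O)N1C(=O)c2ccccc2C1=O` is the one compound with a numbered result in an ADME assay on a cell-free system (plasma, Mus musculus) for metabolic stability, read by HPLC, with a stated time of 120 min, tested at 2 uM (on this read-out higher numbers stand for a longer-lived compound and lower numbers for a shorter-lived compound), where compound 1 gives 0.483 h. Compound 2 `COc1nc2ccccc2n1C(=O)NCCCCc1ccccc1` gives > 2 h in this assay, and that value is a limit, not a number: the limit of > 2 h in this assay, at which 1 of the 2 values shown sits. Compound 3 `O=C(NCCCCc1ccccc1)N1C(=O)c2ccccc2C1=O` has not been measured. It differs from compound 1 by phenyl in place of ethyl on a saturated chain carbon, four bonds along the chain from an amide-type nitrogen. Going by the values given here, since no measured pair sets the size of such a change, only a modest lengthening, at the edge of the scatter, is expected, a 1.6-fold higher number from compound 1 to compound 3 (0.19 log units; within the scatter). Compound 3 is therefore estimated at 0.75 h, in a range from 0.3 h to 1.9 h.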

Compound 3, half-life in the plasma assay: 0.383 h
Estimate against measurement, compound 3: 2.0-fold (0.29 log units) above; measured number inside the range.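

In the plasma assay the change of ethyl to phenyl now has a measured size, a 1.3-fold lower number from compound 1 to compound 3 (0.10 log units; within the scatter), so at this position the swap leaves the half-life within the usual scatter. In a physicochemical assay for metabolic stability, read by HPLC, at pH 4.5, tested at 10 uM (a higher number here means that the compound lasts longer, a lower number that the compound disappears faster), compound 1 gives > 2 h, which is a limit and not a number. In the physicochemical assay compound 3 gives > 2 h, also a limit, so the step there cannot be read: the limit of > 2 h in the physicochemical assay, at which 2 of the 2 values shown sit.

On these data alone, whether an amine or a carboxylic acid in the same place would carry the half-life beyond the scatter remains open. The same is true of a longer chain.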